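Phenyl for Hydroxy: the Step from Compound 1 to Compound 4

The source may report more compounds than this note shows. Statements on the series, on what has been measured and on what is new or still open speak of the compounds shown alone.

Compound 1 `C=CCc1cc(O)c(O)c(CN2CCC(CO)CC2)c1` gives the lowest of the three measured numbers in a functional assay on MIA PaCa-2 cells (Homo sapiens) for inhibition, read by MTT assay, with a stated time of 72 h, tested at 50 uM (a higher number here means more inhibition of growth at the concentration tested, a lower number less inhibition of growth), at 38.6%. Compound 2 `C=CCc1ccc(OCc2cn(-c3ccccc3Cl)nn2)c(O)c1` gives 57.7%, and compound 3 `C=CCc1ccc(OCc2cn(-c3cc(OC)c(OC)c(OC)c3)nn2)c(O)c1` gives 49.8%, both beyond the scatter above compound 1. Neither of these two shares a single-point change with compound 1, so their values say nothing about the change itself. Compound 4 `C=CCc1cc(O)c(O)c(CN2CCC(Cc3ccccc3)CC2)c1` differs from compound 1 in one place: phenyl in place of hydroxy on a saturated chain carbon bound to a saturated ring carbon. Among the compounds with values here, no measured pair shows this change, so its effect in this assay cannot be read from the data. A step of modest size toward more inhibition is expected, a number 9.4 percentage points higher from compound 1 to compound 4 (within the scatter), though it may stay within the scatter. Compound 4 is estimated at 48%, ranging from 30% to 66%.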

Compound 4, percent growth inhibition at one concentration: 90.9%
Estimate against measurement, compound 4: 42.9 percentage points below; the measured number lies above the stated range.
By their numbers in this assay, from the lowest: compound 1; then compounds 3 and 2 (each within the scatter of the next); then compound 4.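

Phenyl in place of hydroxy on a saturated chain carbon bound to a saturated ring carbon gives a number 52.3 percentage points higher from compound 1 to compound 4 (beyond the scatter) in this assay. Within the data shown here, this is the first single-place step, and it shows that the number responds strongly to what this position carries. Nothing shown accounts for the size of the step. One pair cannot separate the loss of hydroxy from the gain of phenyl. Going by these compounds, how a cyclohexyl ring, an amine or a longer chain at this place would read remains open.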